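The compounds below may be only part of what the source reports. "The series", "measured", "known", "first", "only" and "open" are said of these compounds alone.

Measured compounds in a functional assay on HeLa cells (Homo sapiens) for inhibition, read by MTT assay, with a stated time of 24 h; a lower number here means a stronger inhibitor, a higher number a weaker inhibitor:
compound 1 `CCOC(=O)C1=Cc2ccccc2OC1(OCc1cn(-c2ccc(F)cc2)nn1)C(F)(F)F` gives 8400 nM
compound 2 `CCOC(=O)C1=Cc2ccccc2OC1(OCc1cn(CC(=O)Nc2cccc(F)c2)nn1)C(F)(F)F` gives > 150000 nM, which is a limit of the assay and not a number the limit of > 150000 nM in this assay, at which 1 of the 3 values shown sits.
compound 3 `CCOC(=O)C1=Cc2ccccc2OC1(OCc1cn(CC(=O)Nc2ccccc2F)nn1)C(F)(F)F` gives 49900 nM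

Compound 3 carries the higher of the two numbers that are known; the nearest is compound 1, and the gap is a 5.9-fold higher number from compound 1 to compound 3 (0.77 log units; beyond the scatter). The difference between them is the group on the aromatic nitrogen of the shared core. Compound 4 `CCOC(=O)C1=Cc2ccccc2OC1(OCc1cn(-c2ccc(F)c(Cl)c2)nn1)C(F)(F)F` is the next step: 3-chloro-4-fluorophenyl in place of ((2-fluorophenyl)carbamoyl)methyl on an aromatic nitrogen. This largely undoes the change that separated compound 1 from compound 3, so the measured step of a 5.9-fold higher number from compound 1 to compound 3 (0.77 log units; beyond the scatter) bears on it directly, read in reverse; the added chlorine has no measured counterpart among the shown compounds. The step of an at least 3.0-fold lower number from compound 2 to compound 3 (0.47 log units; beyond the scatter) shows that the position of the fluorine on the amide-bearing ring also mattered, but that ring is gone in compound 4. The expectation is therefore a modest fall in the number, with a 6.2-fold lower number from compound 3 to compound 4 (0.80 log units; beyond the scatter) as the estimated step. Compound 4 is expected to give 8000 nM, between 3000 nM and 25000 nM.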

Compound 4, half-maximal inhibitory concentration: 22700 nM
Compound 4: the middle estimate sits 2.8-fold (0.45 log units) below what was measured; measured number inside the range.
By their numbers in this assay, from the lowest: compound 1; then compound 4; then compound 3. At a limit, above all of these: compound 2.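

In this assay, for the compounds shown here, the chloro in place of hydrogen on an aromatic carbon gives a 2.7-fold higher number from compound 1 to compound 4 (0.43 log units; beyond the scatter), the first sign that a change on the ring carried directly by the aromatic nitrogen, rather than a swap of the whole group, can move the number. Even with that chloro, 3-chloro-4-fluorophenyl still compares well with ((2-fluorophenyl)carbamoyl)methyl, giving a 2.2-fold lower number from compound 3 to compound 4 (0.34 log units; beyond the scatter), so the advantage of the directly attached ring seen with compound 1 also appears with a second ring. Compound 2 stands at a limit and not at a number, so an at least 6.6-fold lower number from compound 2 to compound 4 (0.82 log units; beyond the scatter) gives only a bound on the size of that step: the limit of > 150000 nM in this assay, at which 1 of the 4 values shown sits.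

The compounds shown cannot tell why the chloro raises the number, or whether this holds for anything but that one group at that one place on the ring. Bromo or methoxy in place of the chloro remains open, as does an amine or a carboxylic acid on the ring, or a longer chain in place of the methyl link in the carbamoylmethyl group.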